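A few compounds are considered here, and "the series" means these few. Any claim that something is new, unique, unknown or untested is made for them only; others in the source may bear on it.

Going by the values given here, compound 2 `Nc1nc(-c2ccccc2)cn2cc(-c3ccccc3)nc12` gives 180 nM in an assay on cells for displacement of a labelled ligand from adenosine receptor A1 (Homo sapiens), read by scintillation counting, with a stated time of 120 min (a higher number here means a weaker inhibitor, a lower number a stronger inhibitor), the lowest of the two numbers measured so far. Among the compounds with values here, its only neighbour is compound 1 `Nc1nc(Br)cn2cc(-c3ccccc3)nc12`, which gives 420 nM in this assay; the single step between them, a 2.3-fold lower number from compound 1 to compound 2 (0.37 log units; beyond the scatter), came from phenyl in place of bromo on an aromatic carbon. Compound 3 `COc1ccc(-c2cn3cc(-c4ccccc4)nc(N)c3n2)cc1` moves one step further out from compound 2: methoxy in place of hydrogen on an aromatic carbon. Within the data shown here, no measured step bears directly on this change, since the one known step concerned a different position and was itself only modest. With nothing pointing clearly either way, a change no larger than the usual scatter seems the most reasonable expectation. Compound 3 is therefore estimated at 150 nM, with a likely range from 50 nM to 450 nM. This corresponds to an expected step of a 1.2-fold lower number from compound 2 to compound 3 (0.08 log units; within the scatter), which would lie within the scatter.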

Compound 3, inhibition constant: 524 nM
For compound 3 the middle estimate is 3.5-fold (0.54 log units) below the measured one; measured number above the stated range.
By their numbers in this assay, from the lowest: compound 2; then compounds 1 and 3 (each within the scatter of the next).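

Going from phenyl to 4-methoxyphenyl gives a 2.9-fold higher number from compound 2 to compound 3 (0.46 log units; beyond the scatter) in this assay, so this carbon, on which the earlier compounds said nothing, is not indifferent to what it carries. Going by these compounds alone, the one earlier step, a 2.3-fold lower number from compound 1 to compound 2 (0.37 log units; beyond the scatter), showed only that phenyl gave a lower number than bromo, whereas this step shows that a substituent on that phenyl can move the number upward, here by a modest amount beyond the scatter. The compounds shown offer no evidence that would explain this rise. On these data alone, whether the rise belongs to methoxy itself or would come with any group at this place stays open, and a fluoro, a hydroxyl or an amine on the same carbon would help to separate the two. Also open, as far as these compounds go, is whether methoxy would give a similar step elsewhere on that ring.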